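This account rests on a few compounds, and the source may have more. Where it says the series, first, only, none or still open, it means among the compounds named here.

Measured compounds:
- compound 1 `O=C(/C=C/c1ccccc1Cl)Nc1ccc2ncnc(Nc3cccc(Br)c3)c2c1`: 2 ug/mL
- compound 2 `O=C(/C=C/c1ccccc1Cl)Nc1ccc2ncnc(Nc3cccc(Cl)c3)c2c1`: 1.74 ug/mL

In a functional assay on B16-F10 cells (Mus musculus) for inhibition, read by MTT assay, with a stated time of 48 h (on this read-out lower numbers stand for stronger inhibition and higher numbers for weaker inhibition), compound 1 gives 2 ug/mL and compound 2 gives 1.74 ug/mL. Going by the values given here, the one step across the two measured compounds, a 1.1-fold lower number from compound 1 to compound 2 (0.06 log units; within the scatter), lies within the scatter, so the two numbers read as the same. Compound 2 shows the lower of the two numbers, but by a margin within the scatter, so no ranking against compound 1 is claimed.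

Compound 3 `O=C(/C=C/c1ccc([N+](=O)[O-])cc1)Nc1ccc2ncnc(Nc3cccc(Cl)c3)c2c1` follows from compound 2 by the change (4-nitrophenyl in place of 2-chlorophenyl on a double-bonded chain carbon bound to a double-bonded chain carbon). Among the compounds with values here, the only measured step concerns an exchange of halogen on the other aromatic ring and does not bear on this change, which alters the ring on the double-bonded chain. Within the data shown here, no measured pair informs the direction or size of the step, so the expectation rests on the shared core alone: the number for compound 3 in this assay is expected to stay close to that of compound 2, with a wide range because the data hold nothing on this part of the structure. Compound 3 is estimated at 2.5 ug/mL, with a range from 0.7 ug/mL to 9 ug/mL, meaning an expected step of a 1.4-fold higher number from compound 2 to compound 3 (0.16 log units; within the scatter).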

Compound 3, half-maximal inhibitory concentration: 2.05 ug/mL
The estimate for compound 3 lay 1.2-fold (0.09 log units) above the measured number; the measured number falls inside the stated range.
By their numbers in this assay, from the lowest: compounds 2, 1 and 3 (each within the scatter of the next).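

In this assay, the exchange of 2-chlorophenyl for 4-nitrophenyl on a double-bonded chain carbon bound to a double-bonded chain carbon gives a 1.2-fold higher number from compound 2 to compound 3 (0.07 log units; within the scatter). The earlier pair bore only on the halogen on the other aromatic ring, whereas this step shows that at this position a group of 9 heavy atoms with 2 hydrogen-bond acceptors can replace one of 7 heavy atoms with 0 acceptors without a change in the number beyond the scatter. This single step alters both the substituent and its place on the ring, so the two cannot be told apart, and nothing available explains the result.

With every step so far within the scatter, the compounds shown do not reveal what would move the number in this assay at this position. Open questions are whether 4-chlorophenyl would separate the effect of the substituent from that of its place, and whether an amine or a carboxylic acid on this ring, or a longer chain in place of the double-bonded chain, would give a step beyond the scatter.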